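The source may report more compounds than this note shows. Statements on the series, on what has been measured and on what is new or still open speak of the compounds shown alone.

Series notes. In a functional assay, with a stated time of 20 min, tested at 1 mg/mL (on this read-out lower numbers stand for a weaker effect and higher numbers for a stronger effect at the one concentration tested), compound 1 `CC(C)[C@@H]1CC[C@@H](C)C[C@@]12N(C)C(=O)[C@@H]1[C@H]3C(=O)N(c4ccccc4)C(=O)[C@H]3ON12` gives 54.9%, compound 2 `CC(C)[C@@H]1CC[C@@H](C)C[C@@]12N(C)C(=O)[C@@H]1[C@H]3C(=O)N(c4ccc(Cl)cc4)C(=O)[C@H]3ON12` gives 31.7% and compound 3 `Cc1cccc(N2C(=O)[C@H]3[C@H](ON4[C@@H]3C(=O)N(C)[C@@]43C[C@H](C)CC[C@H]3C(C)C)C2=O)c1` gives 38.7%. Compound 3 stands second highest of the three numbers; its nearest neighbour is compound 2, its furthest compound 1. Compound 4 `CC(C)[C@@H]1CC[C@@H](C)C[C@@]12N(C)C(=O)[C@@H]1[C@H]3C(=O)N(c4ccc5ccccc5c4)C(=O)[C@H]3ON12` differs from compound 3 by naphthalen-2-yl in place of 3-methylphenyl on an amide-type nitrogen in a ring. Going by the values given here, the steps that bear on this all alter the group on the amide-type nitrogen in the ring: a number 23.2 percentage points lower from compound 1 to compound 2 (beyond the scatter) and a number 16.2 percentage points lower from compound 1 to compound 3 (beyond the scatter), both modest and beyond the scatter, while a number 7 percentage points higher from compound 2 to compound 3 (within the scatter). Adding a group to that ring lowered the read-out, exchanging one substituted ring for another did not move it beyond the scatter. For compound 4 a step of a number 6.7 percentage points lower from compound 3 to compound 4 (within the scatter) is expected, downward if any. Compound 4 is estimated at 32%, range 15% to 50%.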

Compound 4, a percentage reported as activity, at one concentration (the size of the read-out at that concentration, not a potency): 27.6%
For compound 4 the middle estimate is 4.4 percentage points above the measured one; low and high end bracket the measured number.
By their numbers in this assay, from the lowest: compounds 4, 2 and 3 (each within the scatter of the next, the first and the last beyond it); then compound 1.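

In this assay, going by these compounds alone, naphthalen-2-yl on the amide-type nitrogen gives a number 11.1 percentage points lower from compound 3 to compound 4 (beyond the scatter), the first step between two substituted or enlarged aryl groups to pass the scatter, although a number 4.1 percentage points lower from compound 2 to compound 4 (within the scatter). With a number 27.3 percentage points lower from compound 1 to compound 4 (beyond the scatter), the phenyl of compound 1 keeps a number beyond the scatter above all three other groups at this position. Nothing available explains these steps. The compounds shown leave open how a phenyl bearing an amine or a carboxylic acid, or a saturated cyclohexyl, would read out at this nitrogen.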